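Extending a Pentyl Chain With a Terminal Phenyl Group

This account rests on a few compounds, and the source may have more. Where it says the series, first, only, none or still open, it means among the compounds named here.

Compound 1, `CCCCCNc1cccc2c(S(=O)(=O)Nc3onc(C)c3C)cccc12`: 80 nM
Compound 2, `Cc1noc(N(CC(=O)O)S(=O)(=O)c2ccc(N)cc2)c1C`: > 32000 nM
Compound 3, `Cc1noc(NS(=O)(=O)c2cccc3c(N(C)C)cccc23)c1Cc1ccccc1`: 50000 nM

All three were tested in an assay on VSM-A10 cells for antagonist activity at Endothelin-1 receptor (Rattus norvegicus); a higher number here means a weaker inhibitor, a lower number a stronger inhibitor. Among the numbers shown, compound 1 has the lowest reading in this assay, and its nearest neighbour is compound 3, whose reading is higher by a margin far beyond the usual scatter. Compound 2 sits at the limit of > 32000 nM in this assay, at which 1 of the 3 values shown sits, which is a limit of the assay rather than a number. The remaining compound, compound 4, `Cc1noc(NS(=O)(=O)c2cccc3c(NCCCCCc4ccccc4)cccc23)c1C`, has not yet been measured. It differs from compound 1 in a single place: phenyl in place of hydrogen on a saturated chain carbon, five bonds along the chain from a nitrogen on an aromatic ring. No measured pair among the compounds shown shares this change, so there is no direct precedent for the size of the step it will cause. With nothing to point to, the most reasonable expectation is that the shared core and sulfonamide of compound 1 carry the bulk of the activity and that lengthening the chain with a phenyl group at its end shifts the reading only modestly. Compound 4 is therefore expected to come out near 40 nM, within a range of 8 nM to 250 nM. That estimate corresponds to an expected step of a 2.0-fold lower number from compound 1 to compound 4 (0.30 log units; within the scatter), which would lie within the usual scatter of this assay.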

Compound 4, half-maximal inhibitory concentration: 3050 nM
Estimate against measurement, compound 4: 76-fold (1.88 log units) below; the measured number lies above the stated range.
By their numbers in this assay, from the lowest: compound 1; then compound 4; then compound 3.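

In this assay, phenyl in place of hydrogen on a saturated chain carbon, five bonds along the chain from a nitrogen on an aromatic ring, gives a 38-fold higher number from compound 1 to compound 4 (1.58 log units; beyond the scatter). This is the first single-place comparison among the compounds shown, and it establishes that the far end of the pentyl chain has a large influence on the reading, so the shared core and sulfonamide do not set the reading on their own. Nothing measured here accounts for the size of this step.

Among the compounds shown here, with only this one pair, the effect of the aromatic ring cannot be separated from the effect of the extra length it adds to the chain, and a longer plain alkyl chain or a 3-phenylpropyl chain would help to tell those two apart. On these data alone, whether the end of the chain rejects every added group also remains open, since an amine or a carboxylic acid at that carbon could behave quite differently from phenyl.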